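The source may hold more compounds than are shown below. What is called first, only, known or untested is meant among the compounds shown, and "the series" means these compounds.

Measured compounds:
compound 1 `Cc1nn(C)cc1Nc1nc(N)c2c(C#N)c(N3CCC[C@H]3C)n(C)c2n1` — 2 nM
compound 2 `C[C@@H]1CCCN1c1c(C#N)c2c(N)nccc2n1C` — 2 nM
compound 3 `Cn1c(NCc2ccccc2F)c(C#N)c2c(N)ncnc21` — 120 nM

In an assay on isolated protein for binding affinity to Leucine-rich repeat serine/threonine-protein kinase 2 variant G2019S (Homo sapiens), read by TR-FRET and LanthaScreen, with a stated time of 2 h (a lower number here means a stronger inhibitor, a higher number a weaker inhibitor), compound 1 gives 2 nM. On this number compound 1 is level with compound 2 at the digits printed, and the two together give the lowest numbers of the three. Compound 3 stands furthest away, with a number beyond the scatter above that of compound 1.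

Compound 4 `C[C@@H]1CCCN1c1c(C#N)c2c(N)ncnc2n1C` has not yet been measured in this assay. It differs from compound 1 in one place: hydrogen in place of (1,3-dimethyl-1H-pyrazol-4-yl)amino on an aromatic carbon. Going by the values given here, no step between two measured compounds isolates this change, so its size can only be expected, not read off. The amino-pyrazole that leaves is a substantial group, and its removal might cost some binding; against that, compound 2, which also lacks a substituent of this kind, gives 2 nM, so a strong number without it is plainly possible. A small rise is expected, possibly no more than the scatter: the step from compound 1 to compound 4 is estimated at a 3.0-fold higher number from compound 1 to compound 4 (0.48 log units; beyond the scatter). For compound 4 the expected value in this assay is 6 nM, with a likely range from 1.5 nM to 25 nM.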

Compound 4, inhibition constant: 0.7 nM
Estimate against measurement, compound 4: 8.6-fold (0.93 log units) above, outside the stated range (below it).
By their numbers in this assay, from the lowest: compound 4; then compounds 1 and 2 (each within the scatter of the next); then compound 3.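

In this assay, hydrogen in place of (1,3-dimethyl-1H-pyrazol-4-yl)amino on the aromatic carbon between two ring nitrogen atoms gives a 2.9-fold lower number from compound 1 to compound 4 (0.46 log units; beyond the scatter), a modest step beyond the scatter and the first in the series to isolate a change at this position. On the core of compound 1, the substituent of 8 heavy atoms, with its five-membered aromatic ring, is therefore not required for a low number in this assay, and hydrogen gives the lower number of the two. No measurement at hand accounts for this step.

From the compounds shown here alone, with only hydrogen and this one substituent to compare at this carbon, it remains open how a small group such as an unsubstituted amine, a methyl or a chlorine would compare with either. Going by these compounds, it also remains open whether the (1,3-dimethyl-1H-pyrazol-4-yl)amino group would give a step of similar direction and size on a core that differs elsewhere.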